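The source may report more compounds than this note shows. Statements on the series, on what has been measured and on what is new or still open speak of the compounds shown alone.

Of the compounds shown here, three have been tested in a functional assay on HEL cells (Homo sapiens) (on this read-out lower numbers stand for higher toxicity in this test and higher numbers for lower toxicity in this test), and none of them returned a number. Compound 1 `CCCCCCCCCc1cc2cn(COCCO)c(=O)nc2o1` carries a nonyl chain on its core. In this assay compound 1 gives >= 100000 nM, which is a limit of the assay rather than a measured value. Compound 3 `CCCCCCCCc1cc2cn(COCCO)c(=O)nc2o1` differs from compound 1 only by hydrogen in place of methyl on a saturated chain carbon, eight bonds along the chain from an aromatic carbon. In this assay compound 3 gives > 200000 nM, again a limit. The step that the two limits leave unreadable from compound 1 to compound 3 thus runs between two limits and its size cannot be read.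

Compound 2 `OCCOCn1cc2ccnc-2nc1O` carries no chain on its core. In this assay compound 2 gives > 200000 nM, which is a limit. Compound 2 sits at the limit of > 200000 nM in this assay, at which 2 of the 3 values shown sit. Compound 1 sits at the limit of >= 100000 nM in this assay, at which 1 of the 3 values shown sits.

Compound 4 `CCCCCc1cc2cn(COCCO)c(O)nc-2n1` differs from compound 2 by pentyl in place of hydrogen on an aromatic carbon. Going by the values given here, the only measured step, a step that the two limits leave unreadable from compound 1 to compound 3, alters a chain rather than adding one to a ring carbon, and its size is unreadable, so no measured step bears directly on this change. Since every value shown sits at a limit, no shift beyond the scatter is expected. Compound 4 is therefore expected to give 200000 nM, within a range from 60000 nM to 400000 nM. The expected step of a number no higher from compound 2 to compound 4 (the limit leaves the size open) is estimated to stay within the scatter.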

Compound 4, half-maximal cytotoxic concentration: > 200000 nM
Compound 4 gave a limit, no number (the forecaster's own chance of this, stated with the estimate: 75%); the middle value sits exactly at the limit.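

In this assay compound 4 gives > 200000 nM, which is a limit of the assay. Compound 2 also stands at a limit, and no step can be read between compound 2 and compound 4. The compounds shown leave open whether any of them, with or without a chain on its core, has a half-maximal cytotoxic concentration that can be given as a number.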